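The source may hold more compounds than are shown below. What is called first, only, known or untested is meant among the compounds shown, and "the series" means these compounds.

Compound 1 `C#CCSc1nc(Nc2ccc(Cl)cc2)c2ccncc2n1`: 36700 nM
Compound 2 `C#CCSc1nc(Nc2cccc(Cl)c2)c2ccncc2n1`: 1090 nM

Both compounds were tested in a functional assay on HepG2 cells (Homo sapiens) for inhibition, read by MTT assay, with a stated time of 72 h; on this read-out lower numbers stand for stronger inhibition and higher numbers for weaker inhibition. Going by the values given here, compound 2 holds the lower of the two numbers, and the only comparison available is with compound 1. Next comes compound 3 `C#CCSc1nc(Nc2cccc(O)c2)c2ccncc2n1`, which keeps the shared core and changes one group: hydroxy in place of chloro on an aromatic carbon. Put simply, hydroxy stands in place of chloro on an aromatic carbon, so 3-chlorophenyl becomes 3-hydroxyphenyl.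

Among the compounds with values here, only one measured step bears on this change: a 34-fold lower number from compound 1 to compound 2 (1.53 log units; beyond the scatter). It is large, but it swaps 4-chlorophenyl for 3-chlorophenyl and does not replace the chloro, so it offers no direct guide to a hydroxy group. Within the data shown here, no measured compound carries one. What the step does show is that a change on this ring can move the number a long way in this assay. Among the measured compounds shown here, compound 2, at 1090 nM, is the better of only two values, so a moderate rise is expected, with wide uncertainty in either direction. The expected value for compound 3 is 3000 nM, with an estimated range of 600 nM to 15000 nM. This estimate amounts to an expected 2.8-fold higher number from compound 2 to compound 3 (0.44 log units; beyond the scatter).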

Compound 3, half-maximal inhibitory concentration: 29500 nM
For compound 3 the middle estimate is 9.8-fold (0.99 log units) below the measured one, outside the stated range (above it).
By their numbers in this assay, from the lowest: compound 2; then compounds 3 and 1 (each within the scatter of the next).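

In this assay, hydroxy in place of chloro gives a 27-fold higher number from compound 2 to compound 3 (1.43 log units; beyond the scatter), so a swap of one heavy atom for another at the same ring carbon is enough to produce a large step. The earlier compounds shown here showed only that the place of the chloro on the ring matters, whereas this result shows that the low number of compound 2 also depends on which group sits there. The 3-hydroxyphenyl and 4-chlorophenyl compounds can also be compared, giving a 1.2-fold lower number from compound 1 to compound 3 (0.09 log units; within the scatter), which is within the scatter, so among these three compounds only compound 2, with its 3-chlorophenyl group, stands apart from the others.

Nothing available here explains why the chloro and hydroxy compounds differ so much, even though hydroxy adds a hydrogen-bond donor and a hydrogen-bond acceptor to the count. Also open, going by these compounds, is whether the number of compound 2 depends on chlorine in particular, or whether a methyl group, a methoxy group, an amine or a fluorine atom at this ring carbon would stay close to it or rise towards that of compound 3.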